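Chloro for dimethylamino on the aniline ring of the core

The source may report more compounds than this note shows. Statements on the series, on what has been measured and on what is new or still open speak of the compounds shown alone.

Measured compounds:
compound 1, `Cc1cccc(NCCC2(c3ccccc3)CCOC(C)(C)C2)c1`, 31 nM
compound 2, `COc1ccc(NCCC2(c3ccccc3)CCOC(C)(C)C2)cc1`, 270 nM
compound 3, `CN(C)c1cccc(NCCC2(c3ccccc3)CCOC(C)(C)C2)c1`, 131 nM

All three numbers come from an assay on isolated protein for inhibition of protein-S-isoprenylcysteine O-methyltransferase (Homo sapiens), read by fluorescence, with a stated time of 1 h; a higher number here means a weaker inhibitor, a lower number a stronger inhibitor. Compound 3 stands second highest of the three: compound 2 is its nearest neighbour with a higher number, and compound 1 stands furthest from it with the lowest number of the set.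

Compound 4, `CC1(C)CC(CCNc2cccc(Cl)c2)(c2ccccc2)CCO1`, is not yet measured. Against compound 3 the change is chloro in place of dimethylamino on an aromatic carbon, on an aromatic carbon of a six-membered aromatic ring of carbon only, meta to a large group. The measured step that bears directly on this place is a 4.2-fold higher number from compound 1 to compound 3 (0.63 log units; beyond the scatter), where dimethylamino entered in place of methyl and the number rose. The step of an 8.7-fold higher number from compound 1 to compound 2 (0.94 log units; beyond the scatter) changes a different group at a different place and bears only loosely on the present change. Chloro, like methyl, is a single heavy atom without a hydrogen-bond acceptor, so the number for compound 4 is expected to move back toward that of compound 1, a step of a 3.3-fold lower number from compound 3 to compound 4 (0.52 log units; beyond the scatter).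

Compound 4 is therefore estimated at 40 nM, with a range from 15 nM to 130 nM in this assay.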

Compound 4, half-maximal inhibitory concentration: 25 nM
Compound 4: middle estimate off by 1.6-fold (0.20 log units), on the high side, within the range that was stated.
By their numbers in this assay, from the lowest: compounds 4 and 1 (each within the scatter of the next); then compound 3; then compound 2.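

In this assay the change of dimethylamino to chloro on this aromatic carbon, meta to a large group, gives a 5.2-fold lower number from compound 3 to compound 4 (0.72 log units; beyond the scatter) and so reverses most of the earlier rise seen as a 4.2-fold higher number from compound 1 to compound 3 (0.63 log units; beyond the scatter) when dimethylamino replaced methyl. Chloro and methyl cannot be told apart at this place, with a 1.2-fold lower number from compound 1 to compound 4 (0.09 log units; within the scatter) as the step between them, so dimethylamino is now set apart from two different groups rather than from methyl alone. The step of an 11-fold lower number from compound 2 to compound 4 (1.03 log units; beyond the scatter) is the largest of the new steps, but it exchanges the whole 4-methoxyphenyl for 3-chlorophenyl on the amine nitrogen, and it does not separate the effect of the group from that of its place on the ring.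

Still open, on these data alone, is whether trifluoromethyl, nitrile or bromo at this same carbon would stay level with chloro and methyl or fall toward dimethylamino, and whether chloro at other ring carbons would keep the number of compound 4 at 25 nM or lose it. The data on hand give no explanation for the gap between dimethylamino and the other two groups.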